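Fluoro to methyl: expecting little change

The compounds below may be only part of what the source reports. "The series", "measured", "known", "first", "only" and "open" are said of these compounds alone.

Two compounds sharing one core have numbers in an ADME assay on the whole organism for pharmacokinetics, with Rattus norvegicus as the target (on this read-out lower numbers stand for narrower distribution and higher numbers for wider distribution into tissues), so far. Among the measured compounds shown here, compound 1 (`O=S(=O)(c1ccc(C(F)(F)F)cc1)c1cc(F)c(O)c2ncccc12`) gives 3.8 L/kg and compound 2 (`O=S(=O)(c1ccc(F)cc1)c1cc(F)c(O)c2ncccc12`) gives 3.5 L/kg on this read-out, so compound 2 stands level with its only neighbour, within the scatter of repeated measurements.

The next compound to be measured is compound 3 (`Cc1ccc(S(=O)(=O)c2cc(F)c(O)c3ncccc23)cc1`). Its structure departs from that of compound 2 in a single group: methyl in place of fluoro on an aromatic carbon is the full count, and in words this is methyl in place of fluoro on an aromatic carbon, para to a large group.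

For the measured compounds named here, only one measured step bears on this exchange, and it involves the same place on the molecule. Putting fluoro in place of trifluoromethyl gave a 1.1-fold lower number from compound 1 to compound 2 (0.04 log units; within the scatter) and so barely registered. One small step is thin evidence, and methyl has no measurement of its own at this place yet, so the range must stay wide.

What is expected here is a 1.0-fold higher number from compound 2 to compound 3 (0.01 log units; within the scatter) and thus no step beyond the scatter. The estimate for compound 3 is 3.6 L/kg within an expected range from 2 L/kg to 6.2 L/kg once measured.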

Compound 3, volume of distribution at steady state: 1.2 L/kg
Beside the measured number, compound 3's estimate is 3.0-fold (0.48 log units) above it; the measured number lies below the stated range.
By their numbers in this assay, from the lowest: compound 3; then compounds 2 and 1 (each within the scatter of the next).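

At this position, para to a large group, the choice of group can matter on this assay after all: methyl in place of fluoro gives a 2.9-fold lower number from compound 2 to compound 3 (0.46 log units; beyond the scatter) and methyl in place of trifluoromethyl gives a 3.2-fold lower number from compound 1 to compound 3 (0.50 log units; beyond the scatter) in the same direction. Fluoro and trifluoromethyl stand level with each other here, so that pair alone gave a misleadingly flat picture of this place, and methyl is the only group shown that sets its compound apart. The exchange from 4-fluorophenyl to 4-methylphenyl brings in no ring, no hydrogen-bond donor or acceptor and no net charge, yet the data shown offer no measured explanation for the lower number.

As far as these compounds go, it remains open whether the lower number belongs to methyl alone or also appears with other groups at this place, such as an ethyl group, a methoxy group or an amine. A carboxylic acid here would be a further test, and it is also unknown whether the same exchange would move the number in the same way on a different core.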